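From a boronic acid ether to the bare phenol

The source may report more compounds than this note shows. Statements on the series, on what has been measured and on what is new or still open speak of the compounds shown alone.

Among the compounds with values here, compound 1, `O=C(/C=C/c1ccc(I)cc1)c1ccc(OCB(O)O)cc1`, is one of only two compounds so far measured in a functional assay on MCF7 cells (Homo sapiens) for inhibition; a higher number here means a weaker inhibitor, a lower number a stronger inhibitor. In this assay compound 1 gives 9500 nM, the higher of the two numbers available. Compound 2, `O=C(/C=C/c1ccc(F)c(Cl)c1)c1ccc(B(O)O)cc1`, gives 6000 nM in this assay, and since the two values lie within the usual scatter of each other, neither compound can be called the stronger or weaker inhibitor on this evidence. The unmeasured compound 3, `O=C(/C=C/c1ccc(I)cc1)c1ccc(O)cc1`, keeps the core of compound 1 and differs from it in a single place: a hydrogen atom in place of a group of 4 heavy atoms (1 carbon, 1 boron, 2 oxygen; no ring), on an oxygen on an aromatic ring. Within the data shown here, no pair of measured compounds differing in one place is available, so there is nothing to calibrate how large such a change tends to be in this assay; the account rests only on the two values at hand, which sit close together. Compound 3 is therefore expected to give about 10000 nM in this assay, with a likely range from 3000 nM to 35000 nM. The estimated step of a 1.1-fold higher number from compound 1 to compound 3 (0.02 log units; within the scatter) is accordingly small, not clearly beyond the scatter in either direction.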

Compound 3, half-maximal inhibitory concentration: 7000 nM
Compound 3: the middle estimate sits 1.4-fold (0.15 log units) above what was measured; low and high end bracket the measured number.
By their numbers in this assay, from the lowest: compounds 2, 3 and 1 (each within the scatter of the next).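

Within the data shown here, this is the first pair in this assay that differs in one place, and it gives a first reading for the oxygen on an aromatic ring: replacing the group of 4 heavy atoms (1 carbon, 1 boron, 2 oxygen; no ring) with a hydrogen atom gives a 1.4-fold lower number from compound 1 to compound 3 (0.13 log units; within the scatter) in this series. On this single pair, then, the boron-bearing group on that oxygen can be exchanged for a hydrogen atom with the core of compound 1 unchanged and no difference that stands clear of the scatter. Nothing available here bears on why the two compounds read alike.

One pair cannot show whether this result extends to other groups on that oxygen, such as a methyl group, a longer chain or a carboxylic acid, or whether it holds with other substituents in place of the iodine. Compound 2 differs from compound 1 and compound 3 in more than one place, so it cannot show how a boronic acid attached directly to the aromatic ring compares with the bare phenol.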